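A few compounds are considered here, and "the series" means these few. Any claim that something is new, unique, unknown or untested is made for them only; others in the source may bear on it.

Compound 1 `O=C(NC(=S)NNc1ncnc2ccccc12)c1ccccc1F` gives 2510 nM in a functional assay on KB cells (Homo sapiens) for cytotoxicity, read by MTT assay, with a stated time of 72 h; on this read-out higher numbers stand for weaker inhibition and lower numbers for stronger inhibition. Its number is the lowest of the three shown, yet neither gap is beyond the scatter: compound 2 `COc1cc2ncnc(NNC(=S)NC(=O)c3ccc(Cl)cc3)c2cc1OC` gives 4590 nM in this assay, and compound 3 `COc1cc2ncnc(NNC(=S)NC(=O)c3ccccc3OC)c2cc1OC` gives 3850 nM in this assay. Compound 4 `Cc1ccc(C(=O)NC(=S)NNc2ncnc3ccccc23)cc1` differs from compound 1 by 4-methylphenyl in place of 2-fluorophenyl on a carbonyl carbon. For the measured compounds named here, the only measured step bearing on this position is the one from a chlorinated to a methoxylated aryl on the carbonyl, a 1.2-fold lower number from compound 2 to compound 3 (0.08 log units; within the scatter), which stayed within the scatter. Swapping one aryl for another on that carbonyl is therefore expected to move this assay by no more than the scatter, so compound 4 is estimated at 3000 nM, within 1200 nM to 8000 nM, a step of a 1.2-fold higher number from compound 1 to compound 4 (0.08 log units; within the scatter) that is expected to stay within the scatter.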

Compound 4, half-maximal inhibitory concentration: 10100 nM
Compound 4: the middle estimate sits 3.4-fold (0.53 log units) below what was measured; measured number outside the range, above it.
By their numbers in this assay, from the lowest: compounds 1, 3 and 2 (each within the scatter of the next); then compound 4.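

Swapping one aryl for another on this carbonyl carbon is not always silent in this assay: a 4.0-fold higher number from compound 1 to compound 4 (0.60 log units; beyond the scatter), whereas a 1.2-fold lower number from compound 2 to compound 3 (0.08 log units; within the scatter). The 2-fluorophenyl and 4-methylphenyl groups have equal heavy-atom, hydrogen-bond donor and hydrogen-bond acceptor counts, so these counts do not tell them apart. Nothing shown here accounts for the step.

The compounds shown leave open whether the step follows the loss of fluorine or the arrival of methyl. Plain phenyl or 4-fluorophenyl on that carbonyl carbon could help separate the two.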